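Indol-6-yl added to an otherwise non-cytotoxic benzamide pair

The source may hold more compounds than are shown below. What is called first, only, known or untested is meant among the compounds shown, and "the series" means these compounds.

Compound 1 `COc1cccc(-c2ccc(C(=O)N(Cc3cccc(OCCCCCC(=O)O)c3)C(C)C)cc2)c1`: a limit, > 20900 nM
Compound 2 `CCOC(=O)CCCCCOc1cccc(CN(C(=O)c2ccccc2)C(C)C)c1`: a limit, > 26000 nM

Both values come from an ADME assay on Raji cells (Homo sapiens) for cytotoxicity, read by CellTiter-Glo and resazurin assay, with a stated time of 72 h (on this read-out higher numbers stand for an effect only at larger amounts of compound and lower numbers for an effect already at smaller amounts), and both are limits, not numbers. Compound 2 stands at the limit of > 26000 nM in this assay, at which 1 of the 2 values shown sits. Compound 1 stands at the limit of > 20900 nM in this assay, at which 1 of the 2 values shown sits. So neither compound shows an effect within the tested range, and no step between measured compounds is available. Compound 3 `CCOC(=O)CCCCCOc1cccc(CN(C(=O)c2ccc(-c3ccc4cc[nH]c4c3)cc2)C(C)C)c1` differs from compound 2 by 1H-indol-6-yl in place of hydrogen on an aromatic carbon. For the measured compounds named here, with no measured step to lean on, the expected change in this assay from compound 2 to compound 3 is none beyond the scatter, an at least 1.0-fold lower number from compound 2 to compound 3 (0.01 log units; that floor lies within the scatter). Compound 3 is therefore estimated at 25000 nM, with a range from 6000 nM to 60000 nM, and most likely again only a limit.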

Compound 3, half-maximal effective concentration: > 26000 nM
Compound 3 ended at the assay's limit; the forecaster's own chance of this, stated with the estimate: 60%; middle value at least 1.0-fold (0.01 log units) from the limit.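

The step from compound 2 to compound 3 cannot be read: both values are limits, not numbers. The compounds shown leave open whether 1H-indol-6-yl in place of hydrogen changes anything, and at what amount any effect would begin.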